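Compound 1 to compound 3: pyridin-2-yl for chloromethyl

The source may report more compounds than this note shows. Statements on the series, on what has been measured and on what is new or still open speak of the compounds shown alone.

- Compound 1 (`C/C(=N\Nc1nc(CCl)cs1)c1ccc(Cl)c(Cl)c1`): > 50000 nM (a limit)
- Compound 2 (`C/C(=N\N=c1\scc(-c2ccccc2)n1-c1ccccc1)c1ccc(Cl)c(Cl)c1`): > 50000 nM (a limit)

In an ADME assay on J774 cells (Mus musculus) for cytotoxicity, read by resazurin assay, with a stated time of 72 h (a lower number here means that less compound is tolerated, a higher number that more compound is tolerated), compound 1 gives > 50000 nM as a limit of the assay, not a number. Among the compounds with values here, the only evidence so far is (the limit of > 50000 nM in this assay, at which 2 of the 2 values shown sit), and no measured step sizes a structural change. Compound 3 (`C/C(=N\Nc1nc(-c2ccccn2)cs1)c1ccc(Cl)c(Cl)c1`) carries pyridin-2-yl in place of chloromethyl on an aromatic carbon. A small step towards less tolerated compound, or none beyond the scatter, is expected, estimated as (an at least 1.2-fold lower number from compound 1 to compound 3 (0.09 log units; that floor lies within the scatter)). Compound 3 is expected at 40000 nM in this assay with an estimated range from 12000 nM to 50000 nM as its ends.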

Compound 3, half-maximal cytotoxic concentration: 10100 nM
Estimate against measurement, compound 3: 4.0-fold (0.60 log units) above; measured number outside the range, below it.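

In this assay, this place on the five-membered aromatic ring turns out not to be neutral: pyridin-2-yl in place of chloromethyl gives an at least 4.9-fold lower number from compound 1 to compound 3 (0.69 log units; beyond the scatter). Compound 3 is the first compound shown with a measured number rather than a limit. The step has only a floor, and its full size cannot be read: the limit of > 50000 nM in this assay, at which 2 of the 3 values shown sit.

On these data alone, whether the aromatic ring as such or its ring nitrogen carries the step stays open. Pyridin-3-yl or aminomethyl at this place, on the core of compound 1, would separate the two.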